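The source may hold more compounds than are shown below. What is called first, only, known or untested is meant among the compounds shown, and "the series" means these compounds.

Working notes on the series.

Among the compounds with values here, compound 1 `CC(=O)OC[C@H]1CN(C(C)=O)CCN1S(=O)(=O)c1ccc(F)cc1` carries the sulfonyl and the acetyl on the two ring nitrogens with the acetoxymethyl-bearing ring carbon drawn R. In a functional assay on the whole organism (strain CD-1) with Mus musculus as the target, with a stated time of 20 min (a lower number here means that less compound is needed, a higher number that more compound is needed for the effect), compound 1 gives 1 mg/kg, the only full number in the set. Compound 2 `CC(=O)OCC1CN(S(=O)(=O)c2ccc(F)cc2)CCN1C(C)=O` places the sulfonyl and the acetyl on the opposite nitrogens. In this assay compound 2 reaches only a limit, > 10 mg/kg, so no number stands for it; the set thus holds one value and one limit, (the limit of > 10 mg/kg in this assay, at which 1 of the 2 values shown sits). Within the data shown here, no measured step between compounds differing in one place exists.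

Compound 3 `CC(=O)OCC1CN(C(C)=O)CCN1S(=O)(=O)c1ccc(F)cc1` is the next entry. How it differs from compound 1: the two compounds have the same atoms and bonds; at least one stereo element is drawn with a configuration in one of them and without one in the other: 1 of 1 stereo elements differ; a stereocentre at a saturated ring carbon is drawn R in compound 1 and without a configuration in compound 3. The same atoms and bonds are kept, only the configuration at the saturated ring carbon is undefined. In this assay the step from compound 1 to compound 3 is expected to be a 2.0-fold higher number from compound 1 to compound 3 (0.30 log units; within the scatter), toward a larger dose but not beyond the usual scatter. Compound 3 is thus estimated at 2 mg/kg, between 1 mg/kg and 5 mg/kg.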

Compound 3, minimum effective dose: 0.1 mg/kg
Compound 3: the middle estimate sits 20-fold (1.30 log units) above what was measured, and the stated range ends above it.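

In this assay, the only difference at the saturated ring carbon lies in how its configuration is drawn, and this gives a 10-fold lower number from compound 1 to compound 3 (1.00 log units; beyond the scatter). Within the data shown here, this is the first measured step, and it shows that the way this stereocentre is defined matters for the dose, with atoms and bonds unchanged: the form drawn R is not the one needing the smaller dose. The only thing that can be pointed to for this gap is the drawing itself: the fact that one of compounds 1 and 3 is drawn with a defined configuration and the other without, at the place where they differ

Open, going by these compounds, is how a form drawn S reads in this assay, and so which configuration at this carbon goes with the smaller dose. Also open, on these data alone, is whether the step holds when the acetoxymethyl group on that carbon gives way to a hydroxymethyl group or a carboxylic acid.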